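Series notes: replacement at the ring carbon of compound 3

The source may report more compounds than this note shows. Statements on the series, on what has been measured and on what is new or still open speak of the compounds shown alone.

Measured so far in an assay on isolated protein for inhibition of activin receptor type-2A (Homo sapiens), read by 33P incorporation, with a stated time of 20 min, in the presence of a further agent that is not named here; a higher number here means a weaker inhibitor, a lower number a stronger inhibitor:
compound 1 `COc1cc(-c2cnn3cc(OC)c(-c4cc(C)no4)nc23)ccn1` gives 3000 nM;
compound 2 `CNc1nc2c(-c3ccnc(OC)c3)cnn2cc1C` gives 1300 nM;
compound 3 `COc1cc(-c2cnn3cc(OC)c(C(C)(C)O)nc23)ccn1` gives 2700 nM.

Compound 3 holds the second highest of the three numbers. Its nearest neighbour is compound 1, within the usual scatter of repeated measurement; compound 2 sits at a lower number, and that gap is beyond the scatter.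

Compound 4 `COc1cc(-c2cnn3cc(OC)c([C@@H]4COC(C)(C)C4)nc23)ccn1` is not yet measured. It differs from compound 3 at one site: a group of 7 heavy atoms (6 carbon, 1 oxygen; one five-membered non-aromatic ring with 1 hetero atom) in place of a group of 4 heavy atoms (3 carbon, 1 oxygen; no ring), on an aromatic carbon.

Within the data shown here, one measured step bears on this change, since it falls on the same aromatic carbon of the shared core: a 1.1-fold lower number from compound 1 to compound 3 (0.05 log units; within the scatter). Two quite different groups at that carbon gave numbers indistinguishable within the scatter, and there is no further evidence on how this carbon responds to a saturated ring with one hetero atom. The expectation for compound 4 in this assay is therefore a step of no clear size beyond the scatter, with the range kept wide for want of a second step at this position.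

The estimated number for compound 4 is 2500 nM, with a range of 900 nM to 7000 nM, which corresponds to an expected 1.1-fold lower number from compound 3 to compound 4 (0.03 log units; within the scatter).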

Compound 4, half-maximal inhibitory concentration: 5300 nM
Compound 4: middle estimate off by 2.1-fold (0.33 log units), on the low side; low and high end bracket the measured number.
By their numbers in this assay, from the lowest: compound 2; then compounds 3, 1 and 4 (each within the scatter of the next).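

In this assay, the five-membered non-aromatic ring with 1 hetero atom gives a 2.0-fold higher number from compound 3 to compound 4 (0.29 log units; within the scatter) in place of 1-hydroxy-1-methylethyl, and a 1.8-fold higher number from compound 1 to compound 4 (0.25 log units; within the scatter) in place of 3-methyl-1,2-oxazol-5-yl. Among these compounds, this aromatic carbon next to the ring nitrogen has now carried an open group with a hydrogen-bond donor, a five-membered aromatic ring and a five-membered non-aromatic ring, and no step among compound 1, compound 3 and compound 4 lies beyond the scatter, even with the loss of the donor and the rise from 4 to 7 heavy atoms. No supporting information accounts for this flat response.

On these data alone, whether any group at this carbon moves the number beyond the scatter remains open: an amine or a carboxylic acid here, or the mirror-image form of the ring in compound 4, could test that. Compound 2 differs from the other compounds in more than one place, so the compounds shown do not tell whether a change at this carbon alone could reach its lower number.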